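A few compounds are considered here, and "the series" means these few. Any claim that something is new, unique, unknown or untested is made for them only; others in the source may bear on it.

The study concerns a small set of compounds that share one core and are examined in a functional assay on the whole organism with Mus musculus as the target, at a dose of 100 mg/kg by the intraperitoneal route; on this read-out lower numbers stand for less inhibition and higher numbers for more inhibition at the one dose given (going by the name of the read-out). Compound 2 `NC(=O)/C=C1\CCc2cc(F)cc(F)c21` gives 100% in this assay, the highest of the three numbers obtained. The nearest number comes from compound 3 `O=C(/C=C1\CCc2ccc(F)cc21)NCc1ccccc1`, which gives 17%, a result that lies beyond the scatter below compound 2. Furthest away stands compound 1 `O=C(/C=C1/CCc2ccc(Cl)cc21)NC1CC1`, which gives 0% in this assay, also beyond the scatter. Within the data shown here, no pair of these measured compounds differs in a single place, so no step between them can be separated.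

Compound 4 `NC(=O)/C=C1\CCc2cc(F)ccc21` has not yet been measured. Its structure differs from compound 2 in one place: hydrogen in place of fluoro on an aromatic carbon. A fluoro group of one heavy atom leaves, and a hydrogen atom enters on an aromatic carbon of the fused system, ortho to a fused ring and meta to the remaining fluoro group.

Because compound 2 gives 100% with two fluoro groups present, the loss of one is expected to lower inhibition by a moderate step, estimated as a number 30 percentage points lower from compound 2 to compound 4 (beyond the scatter), plausibly beyond the scatter but not a collapse. Compound 4 is therefore expected to give about 70% in this assay, within a range from 30% to 100%.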

Compound 4, a percentage reported as inhibition, in the whole organism at one dose (the size of the read-out at that dose, not a potency): 100%
Compound 4: middle estimate off by 30 percentage points, on the low side; measured number inside the range.
By their numbers in this assay, from the lowest: compound 1; then compound 3; then compounds 2 and 4 (each within the scatter of the next).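

In this assay, the exchange of fluoro for hydrogen brings no change at the digits printed from compound 2 to compound 4 (within the scatter). Among these compounds, the earlier compounds offered no comparison in a single place, so this is the first reading of any one position on the shared core: at this aromatic carbon, ortho to a fused ring and meta to the remaining fluoro group, the second fluoro group is not needed to keep the read-out at this dose. Nothing measured here bears on why the number stays where it stands.

With a single dose, the compounds shown cannot tell whether compound 2 and compound 4 would separate at lower doses. Also open, on these data alone, is what a chloro group, a methoxy group or an amine would do at this carbon, and what hydrogen in place of the remaining fluoro group would do.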